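The compounds below may be only part of what the source reports. "The series", "measured", "known", "first", "only" and "open" are said of these compounds alone.

Measured compounds:
compound 1 `S=C(N/N=C/c1ccc(Oc2ccc3ccccc3c2)cc1)Nc1ccc(Cl)cc1`: 6.96
compound 2 `O=[N+]([O-])c1ccc(Oc2ccc(/C=N/NC(=S)Nc3ccc(Br)cc3)cc2)cc1`: 5.68
compound 3 `Cc1ccc(Oc2ccc(/C=N/NC(=S)Nc3ccc(Br)cc3)cc2)cc1`: 6.17

In a physicochemical assay for lipophilicity, in phosphate buffer, measured as octanol-water partition, with a stated time of 24 h (a lower number here means a more polar compound, a higher number a more lipophilic compound), compound 3 gives 6.17, the second highest of the three numbers, with compound 2 below it and compound 1 above it. Compound 4 `S=C(N/N=C/c1ccc(Oc2ccc3ccccc3c2)cc1)Nc1ccc(Br)cc1` differs from compound 3 by naphthalen-2-yl in place of 4-methylphenyl on an oxygen on an aromatic ring. Among the compounds with values here, the single measured step, a number 0.49 log units higher from compound 2 to compound 3 (beyond the scatter), concerns a different part of the molecule and does not bear directly on this exchange. Compound 1, which already carries the naphthalen-2-yl group, gives 6.96 in this assay, well above compound 3, and offers the closest guide. A clearly upward step of about a number 0.93 log units higher from compound 3 to compound 4 (beyond the scatter) is therefore expected. Compound 4 is estimated at 7.1, within a range of 6.6 to 7.6.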

Compound 4, partition coefficient: 6.93
The estimate for compound 4 lay 0.17 log units above the measured number; measured number inside the range.
By their numbers in this assay, from the lowest: compound 2; then compound 3; then compounds 4 and 1 (each within the scatter of the next).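

In this assay, naphthalen-2-yl on the oxygen gives a number 0.76 log units higher from compound 3 to compound 4 (beyond the scatter), and in place of 4-nitrophenyl it gives a number 1.25 log units higher from compound 2 to compound 4 (beyond the scatter), so the number at this position depends clearly on the aromatic group carried there. Bromo in place of chloro on the aromatic carbon gives a number 0.03 log units lower from compound 1 to compound 4 (within the scatter), so that exchange does not separate this pair. Nothing measured here gives a reason for these steps. On these data alone, how a pyridinyl ring, or a phenyl ring carrying a carboxylic acid, would read on the same oxygen remains open.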